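Methyl on the saturated ring: a matched-pair note

The source may report more compounds than this note shows. Statements on the series, on what has been measured and on what is new or still open speak of the compounds shown alone.

Measured so far:
compound 1, `O=C1CN(C2CCCC2)c2nc(Nc3ccc(N4CCCCC4)cc3)ncc2N1`, 4440 nM
compound 2, `CC1CCN(c2ccc(Nc3ncc4c(n3)N(C3CCCC3)CC(=O)N4)cc2)CC1`, 8430 nM
compound 3, `CN1C(=O)CN(C2CCCC2)c2nc(Nc3ccc(N4CCCCC4)cn3)ncc21`, 3890 nM

The read-out throughout is a functional assay on HCT-116 cells (Homo sapiens) for inhibition, read by MTT assay, with a stated time of 48 h; a lower number here means a stronger inhibitor, a higher number a weaker inhibitor. From compound 1 to compound 2 the change is methyl in place of hydrogen on a saturated ring carbon, and the measured step is a 1.9-fold higher number from compound 1 to compound 2 (0.28 log units; within the scatter). Compound 3 carries a different core from compound 1; the difference between the two cores is not broken down here. In this assay compound 3 gives 3890 nM while compound 1 gives 4440 nM, a gap within the scatter, so the two cores read as equivalent on present data.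

Compound 4, `CC1CCN(c2ccc(Nc3ncc4c(n3)N(C3CCCC3)CC(=O)N4C)nc2)CC1`, has not yet been measured in this assay. It differs from compound 3 by methyl in place of hydrogen on a saturated ring carbon, the same change, at the same place, that leads from compound 1 to compound 2. Going by the values given here, the expected step is a 1.8-fold higher number from compound 3 to compound 4 (0.26 log units; within the scatter), set to about the size of a 1.9-fold higher number from compound 1 to compound 2 (0.28 log units; within the scatter), on which it rests; only one pair shows the change, so the range is kept wide. Compound 4 is expected to give 7000 nM, between 3000 nM and 16000 nM.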

Compound 4, half-maximal inhibitory concentration: > 30000 nM
Compound 4: only a limit was reported (the forecaster's own chance of this, stated with the estimate: 5%); at least 4.2-fold (0.63 log units) between middle value and limit.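

In this assay compound 4 gives > 30000 nM, which is a limit of the assay and not a number. Methyl in place of hydrogen on a saturated ring carbon, piperidin-1-yl to 4-methylpiperidin-1-yl, gives an at least 7.7-fold higher number from compound 3 to compound 4 (0.88 log units; beyond the scatter), so the change does not carry over at one size from the core of compound 1 to the core of compound 3: the same change on two cores in this assay, a 1.9-fold higher number (0.28 log units; within the scatter) from compound 1 to compound 2 and an at least 7.7-fold higher number (0.88 log units; beyond the scatter) from compound 3 to compound 4, at least 4.0-fold (0.60 log units) apart, beyond the scatter of two such steps This does not show which feature of the core of compound 3 sets the two steps apart or how large the step on that core really is, and with one pair per core it gives no rule for other cores in the series.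

Open, from the compounds shown here alone, is whether a longer chain such as ethyl, or a hydroxyl group, in place of that methyl on the saturated ring carbon would behave like the methyl on either core. Also open, going by these compounds, is the size of the same change on any further core.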